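A few compounds are considered here, and "the series" means these few. Any claim that something is new, unique, unknown or untested is made for them only; others in the source may bear on it.

Compound 1 has the structure `O=C1/C(=C\c2c(Cl)cccc2Cl)c2ccccc2N1c1c(Cl)cccc1Cl`. In a functional assay on L132 cells (Homo sapiens) for cytotoxicity, read by MTT assay, with a stated time of 72 h (a lower number here means that less compound is needed, a higher number that more compound is needed for the effect), compound 1 gives > 100 ug/mL, which is a limit of the assay and not a measured number. For the measured compounds named here, this is also the only solid piece of evidence here, namely (the limit of > 100 ug/mL in this assay, at which 1 of the 2 values shown sits). A second compound, compound 2, with the structure `Cc1ccc2nc(Cl)c(/C=C3\C(=O)N(c4c(Cl)cccc4Cl)c4ccccc43)cc2c1`, carries the entry "not determined" (no result reported) in this assay, so it adds no number to compare with. Going by the values given here, no pair of measured compounds differing in one place exists in this set, so no measured step can be described.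

The compound still to be tested is compound 3, with the structure `O=C1/C(=C\c2ccc(Cl)cc2)c2ccccc2N1c1c(Cl)cccc1Cl`. It differs from compound 1 in one place: 4-chlorophenyl in place of 2,6-dichlorophenyl on a double-bonded chain carbon bound to a double-bonded ring carbon. The change swaps one chlorine-bearing ring for another, keeping the rest of the core intact.

With only a limit for compound 1 to build on, compound 3 is expected to sit close to that limit, with a step of a number no higher from compound 1 to compound 3 (the limit leaves the size open) that is not expected to go beyond the usual scatter in either direction. For compound 3 in this assay the estimate is 100 ug/mL, expected to fall between 40 ug/mL and 300 ug/mL.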

Compound 3, concentration for half-maximal effect: 9 ug/mL
Compound 3: middle estimate off by 11-fold (1.05 log units), on the high side; the whole stated range lies above it.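

In this assay, putting 4-chlorophenyl in place of 2,6-dichlorophenyl on a double-bonded chain carbon bound to a double-bonded ring carbon gives an at least 11-fold lower number from compound 1 to compound 3 (1.04 log units; beyond the scatter), so less compound is needed for the cytotoxic effect. This shows that the shared core does not set the read-out by itself: a change confined to this one ring, with the rest of the molecule intact, is enough to move the result well beyond the usual scatter. The value of compound 1 is a limit of the assay and not a number, so this step has a known minimum but no known full size: the limit of > 100 ug/mL in this assay, at which 1 of the 3 values shown sits.

The two rings differ both in how many chlorines they carry and in where those chlorines sit, so this single step cannot show which of the two differences matters, or whether removing the chlorines altogether would go further. A plain phenyl ring, or a ring carrying an amine or a carboxylic acid in place of chlorine, would be needed to show how much this position tolerates and whether the trend continues in either direction.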